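Aryl substituent swap on the shared core, alpha-1 binding

The source may report more compounds than this note shows. Statements on the series, on what has been measured and on what is new or still open speak of the compounds shown alone.

Measured so far in an assay on isolated protein for binding affinity to Adrenergic receptor alpha-1 (Homo sapiens); on this read-out lower numbers stand for stronger inhibition and higher numbers for weaker inhibition:
compound 1 `COc1ccccc1N1CCN(CCn2c(=O)[nH]c3[nH]c(-c4ccccc4C)cc3c2=O)CC1`: 1.19 nM
compound 2 `COc1ccc(-c2cc3c(=O)n(CCN4CCN(c5ccccc5OC)CC4)c(=O)[nH]c3[nH]2)cc1`: 5.47 nM

For the measured compounds named here, compound 2 carries the higher of the two numbers in this assay; its only neighbour is compound 1, which lies below it by a 4.6-fold higher number from compound 1 to compound 2 (0.66 log units; beyond the scatter), a step that rests on 4-methoxyphenyl in place of 2-methylphenyl on an aromatic carbon.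

Compound 3 `COc1ccccc1N1CCN(CCn2c(=O)[nH]c3[nH]c(-c4ccc(Cl)cc4)cc3c2=O)CC1` is the next member to be measured. From compound 2 it differs by chloro in place of methoxy on an aromatic carbon. Going by the values given here, the single measured step does not cover this change: it swaps one aryl group for another with a different substituent at a different place, whereas here the substituent is exchanged on the same aromatic carbon, para to a large group. Among the compounds with values here, no step therefore speaks directly to chloro in place of methoxy, and the precedent only shows that the group on this aryl ring can shift the number by a modest amount.

The expectation for compound 3 is a number not far from compound 2, possibly somewhat lower, with the step from compound 2 to compound 3 estimated at a 1.6-fold lower number from compound 2 to compound 3 (0.19 log units; within the scatter). The estimated value for compound 3 in this assay is 3.5 nM, with a range from 1.2 nM to 10 nM.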

Compound 3, inhibition constant: 4.08 nM
Beside the measured number, compound 3's estimate is 1.2-fold (0.07 log units) below it; the range from low to high includes it.
By their numbers in this assay, from the lowest: compound 1; then compounds 3 and 2 (each within the scatter of the next).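

In this assay, the exchange of methoxy for chloro on the aromatic carbon para to a large group gives a 1.3-fold lower number from compound 2 to compound 3 (0.13 log units; within the scatter), so the two 4-substituted phenyl compounds cannot be told apart on this read-out, although the two groups differ in heavy atoms and hydrogen-bond acceptors. The comparison with the 2-methylphenyl compound gives a 3.4-fold higher number from compound 1 to compound 3 (0.54 log units; beyond the scatter), which joins a 4.6-fold higher number from compound 1 to compound 2 (0.66 log units; beyond the scatter) as a second step beyond the scatter in the same direction, and neither of the 4-substituted phenyl compounds shown goes against this. No measurement available here bears on the reason for these numbers.

Each step away from compound 1 changes both the substituent and its place on the ring, so the compounds shown leave open whether the place or the group itself accounts for the higher numbers; 4-methylphenyl or 2-chlorophenyl would separate the two. Also open, going by these compounds, is how far the flat response at this position extends to groups of another kind, such as an amine or a carboxylic acid on the same aromatic carbon.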